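A few compounds are considered here, and "the series" means these few. Any claim that something is new, unique, unknown or untested is made for them only; others in the source may bear on it.

Measured in an ADME assay on L132 cells (Homo sapiens) for inhibition, read by MTT assay, with a stated time of 72 h; on this read-out higher numbers stand for weaker inhibition of growth and lower numbers for stronger inhibition of growth:
- Compound 1 `Nc1n[nH]c2cccc(C#Cc3cccc(NC(=O)c4cccc(C(F)(F)F)c4)c3)c12`: > 100000 nM. This entry is a limit of the assay, not a number.
- Compound 2 `Cc1cn(-c2cc(C(=O)Nc3cccc(C#Cc4cccc5[nH]nc(N)c45)c3)cc(C(F)(F)F)c2)cn1`: 10900 nM.

For the measured compounds named here, compound 2 holds the only true number so far in this assay, 10900 nM. Going by the values given here, for compound 1 the only reading is the limit of > 100000 nM in this assay, at which 1 of the 2 values shown sits.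

Compound 3 `Nc1n[nH]c2cccc(C#Cc3cccc(NC(=O)c4cc(F)cc(C(F)(F)F)c4)c3)c12` has not yet been measured. It carries fluoro in place of 4-methyl-1H-imidazol-1-yl on an aromatic carbon, meta to a trifluoromethyl group (fluoro in place of 4-methyl-1H-imidazol-1-yl on an aromatic carbon).

Among the compounds with values here, one measured step bears on this place: an at least 9.1-fold lower number from compound 1 to compound 2 (0.96 log units; beyond the scatter), where 4-methyl-1H-imidazol-1-yl took the place of hydrogen. Within the data shown here, compound 3 gives that group up again, but fluoro rather than hydrogen enters, and no measured compound carries fluoro there. A move towards higher numbers in this assay, beyond the scatter, is therefore expected, of a size comparable to the measured step but uncertain. A reading at the limit of the assay is also a real possibility.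

The estimated step is a 4.6-fold higher number from compound 2 to compound 3 (0.66 log units; beyond the scatter).

For compound 3 the expected value is 50000 nM, with an estimated range of 12000 nM to 100000 nM.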

Compound 3, concentration for 50% growth inhibition: > 100000 nM
Compound 3: a limit, no number; the forecaster's own chance of this, stated with the estimate: 45%; middle value at least 2.0-fold (0.30 log units) from the limit.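

In this assay, compound 3 gives > 100000 nM, which is a limit of the assay and not a number. For the compounds shown here, with fluoro in place of 4-methyl-1H-imidazol-1-yl on an aromatic carbon, meta to a trifluoromethyl group, the result is an at least 9.1-fold higher number from compound 2 to compound 3 (0.96 log units; beyond the scatter), so the only true number does not survive the loss of that group when fluoro enters. Fluoro at this place therefore leaves the reading at the limit, as hydrogen does in compound 1, and the step between those two entries cannot be read, both being limits: the limit of > 100000 nM in this assay, at which 2 of the 3 values shown sit.

From the compounds shown here alone, how far compound 1 and compound 3 lie beyond the limit remains unknown, and any difference between hydrogen and fluoro at this place stays hidden. Also open, going by these compounds, is whether the lower number depends on 4-methyl-1H-imidazol-1-yl itself or would also come with another group here, such as an unmethylated imidazole, an amine or a carboxylic acid, and so far it rests on a single compound.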